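This account rests on a few compounds, and the source may have more. Where it says the series, first, only, none or still open, it means among the compounds named here.

Compound 1 `C=CCCCCOc1ccccc1-c1cnc(OCCC=C)n1C` sits at the lower of the two numbers seen so far: in a functional assay on T98G cells (Homo sapiens) for inhibition, read by colorimetric assay and MTT assay, with a stated time of 72 h (a higher number here means a weaker inhibitor, a lower number a stronger inhibitor), compound 1 gives 29000 nM, while compound 2 `C=CCCCCOc1ccc(OC)cc1-c1cnc(OCCC=C)n1C` gives 74000 nM, a change of a 2.6-fold higher number from compound 1 to compound 2 (0.41 log units; beyond the scatter). That single step concerns a methoxy on the aromatic ring and says nothing about the chain on the other side of the core. Compound 3 `C=CCCCCOc1ccccc1-c1cnc(OCCOCC=C)n1C` alters that chain: allyloxy in place of vinyl on a saturated chain carbon, two bonds along the chain from an oxygen on an aromatic ring. Within the data shown here, no measured pair changes the same chain, so there is no step to lean on. With only a shift of the double bond outward and an added oxygen in the chain, the expected step of no change at the digits printed from compound 1 to compound 3 (within the scatter) from compound 1 is none beyond the scatter. Compound 3 is therefore estimated to give 29000 nM in this assay, with a range from 10000 nM to 85000 nM.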

Compound 3, half-maximal inhibitory concentration: 65000 nM
Compound 3: the middle estimate sits 2.2-fold (0.35 log units) below what was measured; the range from low to high includes it.
By their numbers in this assay, from the lowest: compound 1; then compounds 3 and 2 (each within the scatter of the next).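

In this assay the chain changed in compound 3 proves not to be indifferent: allyloxy in place of vinyl on a saturated chain carbon, two bonds along the chain from an oxygen on an aromatic ring, gives a 2.2-fold higher number from compound 1 to compound 3 (0.35 log units; beyond the scatter) and so moves the number beyond the scatter. The methoxy step could not show this, as it touched only the aromatic ring; here a change that still carries a double bond outside aromatic rings, and brings in an oxygen, also leads to a weaker inhibitor. Nothing at hand explains this shift. Compound 3 alone cannot separate the added oxygen from the added chain length. As far as these compounds go, whether an amine or a carboxylic acid in place of allyloxy at this position would give a lower number also remains open.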